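Changing the aryl group on the sulfonyl sulfur

This account rests on a few compounds, and the source may have more. Where it says the series, first, only, none or still open, it means among the compounds named here.

Measured so far:
compound 1, `COc1ccc(S(=O)(=O)NCCCN2CCC(CCC(=O)c3cc(Cl)c(N)cc3OC)CC2)cc1`: "not active" (no number reported)
compound 2, `COc1cc(N)c(Cl)cc1C(=O)CCC1CCN(CCNS(=O)(=O)c2cc(Br)c(N)c(Br)c2)CC1`: 83%

Of the compounds shown here, two have been tested in an assay on HEK293 cells for displacement of a labelled ligand from 5-hydroxytryptamine receptor 6 (Homo sapiens), with a stated time of 60 min, tested at 1 uM, in the presence of a further agent that is not named here; a higher number here means a stronger effect of the compound at the concentration tested, a lower number a weaker effect. Compound 1 is reported as "not active" (no number reported), with no number attached. Within the data shown here, compound 2 gives 83% and is therefore the only compound of the pair with a numerical read-out; it stands alone at the top of what is known.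

Compound 3, `COc1ccc(S(=O)(=O)NCCN2CCC(CCC(=O)c3cc(Cl)c(N)cc3OC)CC2)cc1OC`, has not yet been measured. Compared with compound 2 it carries 3,4-dimethoxyphenyl in place of 4-amino-3,5-dibromophenyl on a sulfonyl sulfur. Among the measured compounds shown here, no step between measured compounds is available to calibrate this change; the only hint is that compound 1, which also carries a methoxy-bearing phenyl on the sulfonyl sulfur, gives "not active" (no number reported), although compound 1 differs from compound 3 in more than one place.

In this assay compound 3 is expected to show a number 33 percentage points lower from compound 2 to compound 3 (beyond the scatter). The estimate for compound 3 is 50%, with a likely range from 15% to 80%.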

Compound 3, a percentage reported as inhibition, at one concentration (the size of the read-out at that concentration, not a potency): 58%
The estimate for compound 3 lay 8 percentage points below the measured number; low and high end bracket the measured number.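

Among these compounds, the change on the sulfonyl sulfur gives the first step that can be read at this position: in this assay, 3,4-dimethoxyphenyl in place of 4-amino-3,5-dibromophenyl gives a number 25 percentage points lower from compound 2 to compound 3 (beyond the scatter). The read-out therefore survives the loss of the amine and both bromines, since compound 3 still gives 58%, so the 4-amino-3,5-dibromophenyl group is not needed for a measurable effect at the concentration tested, although the step beyond the scatter shows that the aryl group on the sulfonyl sulfur does affect the read-out. No measurement on hand explains the size of this step.

A single swap exchanges the whole aryl group, so it cannot show whether the amine, the bromines or the methoxy groups account for the difference, and a 3,5-dibromophenyl or a 4-aminophenyl group on the same sulfur would be needed to separate these contributions. Going by these compounds, compound 1 differs from compound 3 in more than one place, so its result cannot be assigned to any single change, and the effect of the chain between the sulfonamide nitrogen and the shared core remains open.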